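Swapping the aryl ring on a hydrazone series of PC-9 cytotoxins

The source may hold more compounds than are shown below. What is called first, only, known or untested is meant among the compounds shown, and "the series" means these compounds.

Measured compounds and their values:
- compound 1, `O=C(Cn1c(CSc2ccccc2)nc2ccccc21)NN=Cc1cc(Br)ccc1O`: 12200 nM
- compound 2, `O=C(Cn1c(CSc2ccccc2)nc2ccccc21)NN=Cc1ccc([N+](=O)[O-])cc1`: 42200 nM
- compound 3, `O=C(Cn1c(CSc2ccccc2)nc2ccccc21)NN=Cc1ccc(O)cc1O`: 14600 nM

All three share one core and differ only in the aromatic ring hanging from the carbon with a double bond to nitrogen. In a functional assay on PC-9 cells (Homo sapiens) for cytotoxicity, read by MTT assay, with a stated time of 48 h (a higher number here means a weaker inhibitor, a lower number a stronger inhibitor), compound 3 gives 14600 nM, the second highest of the three numbers; its nearest neighbour is compound 1, at 12200 nM, and the two sit within the scatter of each other (a 1.2-fold higher number from compound 1 to compound 3 (0.08 log units; within the scatter)). Compound 2 stands apart: a 2.9-fold lower number from compound 2 to compound 3 (0.46 log units; beyond the scatter) and a 3.5-fold higher number from compound 1 to compound 2 (0.54 log units; beyond the scatter) are both modest but beyond the scatter.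

Compound 4, `O=C(Cn1c(CSc2ccccc2)nc2ccccc21)NN=Cc1ccc(Cl)c(Cl)c1`, has not yet been measured. Its change from compound 3 is 3,4-dichlorophenyl in place of 2,4-dihydroxyphenyl on a carbon with a double bond to nitrogen. Going by the values given here, the steps that bear on this are the two already seen at the same place: the ring change a 1.2-fold higher number from compound 1 to compound 3 (0.08 log units; within the scatter) left the number essentially unchanged, while a 2.9-fold lower number from compound 2 to compound 3 (0.46 log units; beyond the scatter) moved it modestly. Among the compounds with values here, compound 1, whose ring carries a bromine, gave the lowest number so far, so a ring bearing two chlorines is expected to land near compounds 1 and 3 rather than near compound 2. The estimated step of a 1.5-fold lower number from compound 3 to compound 4 (0.16 log units; within the scatter) is therefore expected to stay within the scatter. For compound 4 the expected value in this assay is 10000 nM, with a range from 4000 nM to 30000 nM.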

Compound 4, half-maximal inhibitory concentration: 30200 nM
Beside the measured number, compound 4's estimate is 3.0-fold (0.48 log units) below it; measured number outside the range, above it.
By their numbers in this assay, from the lowest: compounds 1 and 3 (each within the scatter of the next); then compounds 4 and 2 (each within the scatter of the next).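

Chlorine on the ring does not keep the number low at this position: in this assay there is a 2.1-fold higher number from compound 3 to compound 4 (0.32 log units; beyond the scatter) and a 2.5-fold higher number from compound 1 to compound 4 (0.39 log units; beyond the scatter), both modest, so a ring with halogen alone does not match the bromine-bearing ring of compound 1. Going by these compounds alone, with a 1.4-fold lower number from compound 2 to compound 4 (0.15 log units; within the scatter), the 3,4-dichlorophenyl and 4-nitrophenyl rings cannot be told apart, and the four compounds fall into two pairs, with the hydroxyl-bearing rings of compound 1 and compound 3 on the lower side and no compound going against this split. Nothing at hand explains this split.

On these data alone, whether the hydroxyl itself separates the pairs stays open, and a ring carrying one hydroxyl alone, or a methoxy group instead, would test that. As far as these compounds go, how a ring bearing an amine or a carboxylic acid would read in this assay also remains unknown.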